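Swapping a Thiophene Thioether for a Methanesulfonamide

The source may report more compounds than this note shows. Statements on the series, on what has been measured and on what is new or still open speak of the compounds shown alone.

Values in an ADME assay on L02 cells (Homo sapiens) for cytotoxicity, read by MTT assay, with a stated time of 48 h; a higher number here means a weaker inhibitor, a lower number a stronger inhibitor:
compound 1 `CCN1CCN(C[C@H]2CN(c3ccc(-n4cc(-c5ccccn5)cn4)c(F)c3)C(=O)O2)CC1`: 99 ug/mL
compound 2 `O=C1O[C@@H](CSc2cccs2)CN1c1ccc(-n2cc(-c3ccccn3)cn2)c(F)c1`: > 400 ug/mL (a limit, not a number)

Compound 2 gives > 400 ug/mL, and this is a limit of the assay rather than a number. It therefore stands at the limit of > 400 ug/mL in this assay, at which 1 of the 2 values shown sits.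

The next structure is compound 3 `CS(=O)(=O)NC[C@H]1CN(c2ccc(-n3cc(-c4ccccn4)cn3)c(F)c2)C(=O)O1`, which keeps the shared core. Here methanesulfonamido takes the place of (thiophen-2-yl)sulfanyl on a saturated chain carbon bound to a saturated ring carbon: methanesulfonamido in place of (thiophen-2-yl)sulfanyl on a saturated chain carbon bound to a saturated ring carbon. The entering group has no ring, and like the group it replaces, it has no net charge.

Going by the values given here, only one measured step touches this place: an at least 4.0-fold higher number from compound 1 to compound 2 (0.60 log units; beyond the scatter), which lies beyond the scatter. In that step, (thiophen-2-yl)sulfanyl replaced 4-ethylpiperazin-1-yl. Methanesulfonamido appears in neither compound, so this step is only a loose guide. It shows that a change here can move the reading, so a modest move to a lower number is expected in this assay.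

The estimated step is an at least 1.4-fold lower number from compound 2 to compound 3 (0.15 log units; that floor lies within the scatter). For compound 3 the expected value is 280 ug/mL, with an estimated range of 120 ug/mL to 650 ug/mL.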

Compound 3, half-maximal inhibitory concentration: > 400 ug/mL
Compound 3: a limit, no number; the forecaster's own chance of this, stated with the estimate: 45%; middle value at least 1.4-fold (0.15 log units) away from the limit.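

In this assay, compound 3 gives > 400 ug/mL, which is a limit of the assay and not a number. The step that can be read is an at least 4.0-fold higher number from compound 1 to compound 3 (0.60 log units; beyond the scatter), so replacing 4-ethylpiperazin-1-yl with methanesulfonamido, a group with no ring, moves the number in the same direction as the earlier change to (thiophen-2-yl)sulfanyl, a group with a five-membered aromatic ring. The step between compound 2 and compound 3 cannot be read, and these two groups cannot be ranked against each other, as both compounds sit at the same limit: the limit of > 400 ug/mL in this assay, at which 2 of the 3 values shown sit.

On these data alone, it remains open whether the lower number of compound 1 depends on the whole 4-ethylpiperazin-1-yl group or only on part of it, which a simple dimethylamino group or a morpholine ring at this place could help to separate. Also open, as far as these compounds go, is whether a carboxylic acid or a longer carbon chain on the same saturated chain carbon would give a number or would also stay at the limit.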